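Hydroxy addition to the isobutyramide triarylethylene series

A few compounds are considered here, and "the series" means these few. Any claim that something is new, unique, unknown or untested is made for them only; others in the source may bear on it.

Measured compounds:
compound 1, `CC/C(=C(/c1ccc(NC(=O)C(C)C)cc1)c1ccc(OC)cc1)c1ccccc1` — in a functional assay on MCF7 cells (Homo sapiens) for inhibition, read by trypan blue exclusion, with a stated time of 72 h (on this read-out higher numbers stand for weaker inhibition of growth and lower numbers for stronger inhibition of growth), compound 1 reaches only the limit > 30000 nM.
compound 2, `CC/C(=C(/c1ccccc1)c1ccc(NC(=O)C(C)C)cc1)c1ccccc1` — in this assay compound 2 likewise reaches only the limit > 30000 nM.
compound 3, `CC/C(=C(\c1ccc(NC(=O)C(C)C)cc1)c1ccc(OC)cc1)c1ccccc1` — in this assay compound 3 gives 27900 nM.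

Compound 3 is the only one of the three with a number rather than a limit, so it is the reference point of the set. Both measured steps end at it. The step of an at least 1.0-fold lower number from compound 1 to compound 3 (0.03 log units; that floor lies within the scatter) and the step of an at least 1.0-fold lower number from compound 2 to compound 3 (0.03 log units; that floor lies within the scatter) each sit on a floor within the scatter, because of the limit of > 30000 nM in this assay, at which 2 of the 3 values shown sit; the first of them rests on (the fact that compounds 1 and 3 differ only in the configuration as drawn).

Compound 4, `CC/C(=C(\c1ccc(NC(=O)C(C)C)cc1)c1ccc(OC)cc1)c1ccc(O)cc1`, differs from compound 3 by hydroxy in place of hydrogen on an aromatic carbon. Among the measured compounds shown here, neither measured step concerns a hydroxy group, so none bears directly on this change; both show only that the core tolerates its substitution pattern without visible movement. For compound 4 a modest gain is expected, with the step of a 1.9-fold lower number from compound 3 to compound 4 (0.27 log units; within the scatter) in this assay, and a real chance of a limit again. The estimate for compound 4 in this assay is 15000 nM, between 3000 nM and 40000 nM.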

Compound 4, concentration for 50% growth inhibition: 9000 nM
Estimate against measurement, compound 4: 1.7-fold (0.22 log units) above; low and high end bracket the measured number.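

In this assay, among the compounds shown here, the change from phenyl to 4-hydroxyphenyl gives a 3.1-fold lower number from compound 3 to compound 4 (0.49 log units; beyond the scatter), the only step in the set that joins two numbers and the only one beyond the scatter. The two earlier steps remain floors and could show no movement of this kind, because they are capped by this: the limit of > 30000 nM in this assay, at which 2 of the 4 values shown sit. This position, on an aromatic carbon para to a large group, is therefore one where a single added hydroxy moves the read-out measurably, although the step is modest and rests on one pair of compounds.

Whether this gain is specific to hydroxy stays open, since an amine, a fluorine atom or a carboxylic acid at the same place would be needed to separate it from substitution in general, and the compounds shown say nothing about why hydroxy has this effect. For the compounds shown here, also open is whether the same step holds in the opposite double-bond configuration, the one drawn in compound 1, where a hydroxy counterpart would be needed for a direct comparison.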